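What Happens When 3-Carboxyphenyl Replaces Methyl?

The source may report more compounds than this note shows. Statements on the series, on what has been measured and on what is new or still open speak of the compounds shown alone.

Two small amides open this story: compound 1 (`CCCSc1ncccc1C(=O)NC1CCCCC1`) and compound 2 (`CCCSc1c(C(=O)NC2CCCCC2)cnn1C`). In an in vivo ADME assay on the whole organism for pharmacokinetics, with Rattus norvegicus as the target (a higher number here means that a larger share of the oral dose reaches the circulation, a lower number that a smaller share of the oral dose reaches the circulation), compound 1 gives 0%. In this assay compound 2 gives 0%, level with compound 1, so neither one stands apart from the other.

Compound 3 (`CCCSc1c(C(=O)NC2CCCCC2)cnn1-c1cccc(C(=O)O)c1`) has not yet been measured. It departs from compound 2 in one place: on an aromatic nitrogen, 3-carboxyphenyl stands in place of methyl (3-carboxyphenyl in place of methyl on an aromatic nitrogen). The new group sits next to the ring atom that bears the propylsulfanyl group.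

Among the compounds with values here, no measured pair shows what a change at this place does, so any forecast here carries wide margins. Compound 2 sits at 0%, which leaves no room for a drop, so any real movement can only be upward. A rise beyond the usual scatter is expected, and it is estimated as a number 25 percentage points higher from compound 2 to compound 3 (beyond the scatter). For compound 3 the estimated value in this assay is 25%, with an expected range from 5% to 60%.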

Compound 3, oral bioavailability in the Rattus norvegicus assay: > 100%
Compound 3: no number, only a limit; the forecaster's own chance of this, stated with the estimate: 5%; at least 75 percentage points between middle value and limit.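

In the Rattus norvegicus assay, 3-carboxyphenyl in place of methyl on an aromatic nitrogen gives a number at least 100 percentage points higher from compound 2 to compound 3 (beyond the scatter), the only step at this place among the compounds shown, since compounds 1 and 2 offered no pair to read. On these data alone, for compound 3, the reading of > 100% in the Rattus norvegicus assay is a limit of the assay and not a number, so the step marks a large rise whose true size stays unknown. In a physicochemical assay for lipophilicity, using the shake flask method, at pH 7.4 (a higher number here means a more lipophilic compound, a lower number a more polar compound), compound 2 gives 3 and compound 3 gives 0.7. The same change also leaves compound 3 far less lipophilic in the physicochemical assay: the measured distribution coefficient of compound 2, 3, and of compound 3, 0.7, a number 2.30 log units lower (beyond the scatter)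

This single pair cannot show which part of the new group matters, the carboxylic acid or the six-membered aromatic ring that carries it, and a plain phenyl group on the same aromatic nitrogen would separate the two. Nor can one pair tell whether the lower distribution coefficient and the higher oral bioavailability are linked or merely happen to appear together, a question that would need further groups at this place, such as a pyridyl ring or a longer chain ending in a carboxylic acid.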